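Adding a Methoxy Group to the Core of Compound 3

The compounds below may be only part of what the source reports. "The series", "measured", "known", "first", "only" and "open" are said of these compounds alone.

Compound 1 `C=C(Br)C(=O)Nc1ccc(C(=O)/C=C/c2ccccc2OC)cc1` gives 1700 nM in a functional assay on L1210 cells (Mus musculus) for antiproliferative activity, with a stated time of 48 h; a lower number here means a stronger inhibitor, a higher number a weaker inhibitor.
Compound 2 `C=C(Br)C(=O)Nc1ccc(C(=O)/C=C/c2cccc(OC)c2OC)cc1` gives 1100 nM in this assay.
Compound 3 `Nc1ccc(C(=O)/C=C/c2ccccc2)cc1` gives 14000 nM in this assay.

From compound 1 to compound 2 the change is methoxy in place of hydrogen on an aromatic carbon, and it made a 1.5-fold lower number from compound 1 to compound 2 (0.19 log units; within the scatter). Compound 4 `COc1cccc(/C=C/C(=O)c2ccc(N)cc2)c1` is not yet measured. It arises from compound 3 by methoxy in place of hydrogen on an aromatic carbon, the same kind of change, though the surroundings differ: in the earlier pair the place was ortho to a methoxy group and meta to a large group, here it is meta to a large group. How the core of compound 3 differs from the core of compound 1 is not broken down here; compound 3 simply gives a far higher number than compound 1 or compound 2. Because the same kind of change made a 1.5-fold lower number from compound 1 to compound 2 (0.19 log units; within the scatter), the step from compound 3 to compound 4 is expected to be a 1.5-fold lower number from compound 3 to compound 4 (0.17 log units; within the scatter), within the scatter. Compound 4 is therefore expected to give about 9500 nM, likely between 4000 nM and 24000 nM.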

Compound 4, half-maximal inhibitory concentration: 22000 nM
Beside the measured number, compound 4's estimate is 2.3-fold (0.36 log units) below it, and the stated range covers the measured number.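

In this assay, the methoxy change gave a 1.6-fold higher number from compound 3 to compound 4 (0.20 log units; within the scatter), so compound 3 and compound 4 cannot be told apart here. The two steps carry opposite signs, yet the gap between them is no larger than the scatter allows, so on both cores the change shows no clear effect: the same change on two cores in this assay, a 1.5-fold lower number (0.19 log units; within the scatter) from compound 1 to compound 2 and a 1.6-fold higher number (0.20 log units; within the scatter) from compound 3 to compound 4, 2.4-fold (0.39 log units) apart, within the scatter of two such steps This does not show that methoxy is without effect elsewhere in the series, and with neither step beyond the scatter, it gives no direction that could be carried to another core.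

Still open, going by these compounds, is whether a different group at this place on compound 3, such as hydroxyl or chlorine, would give a step beyond the scatter. Also open, on these data alone, is which difference between the core of compound 3 and the core of compound 1 goes with their different numbers.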